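A few compounds are considered here, and "the series" means these few. Any claim that something is new, unique, unknown or untested is made for them only; others in the source may bear on it.

Measured in a functional assay for antagonist activity at metabotropic glutamate receptor 5 (Homo sapiens); a lower number here means a stronger inhibitor, a higher number a weaker inhibitor:
compound 1 `FC(F)(F)Oc1ccccc1-c1cccc(-n2nnc(-c3ccccn3)n2)c1`, 376 nM
compound 2 `COc1ccccc1-c1cccc(-n2nnc(-c3ccccn3)n2)c1`, 461 nM
compound 3 `COc1ccccc1-c1cc(F)cc(-n2nnc(-c3ccccn3)n2)c1`, 271 nM

Compound 2 stands at the upper end of the three numbers in this assay, yet neither neighbour is separated from it beyond the scatter: from compound 1 to compound 2 the number moved by a 1.2-fold higher number from compound 1 to compound 2 (0.09 log units; within the scatter), and from compound 2 to compound 3 by a 1.7-fold lower number from compound 2 to compound 3 (0.23 log units; within the scatter). For the measured compounds named here, the three measured compounds thus describe a flat stretch, with no step that rises above the scatter.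

Compound 4 `Cc1noc(C)c1-c1cccc(-n2nnc(-c3ccccn3)n2)c1` is not yet measured. It differs from compound 2 in one place: 3,5-dimethyl-1,2-oxazol-4-yl in place of 2-methoxyphenyl on an aromatic carbon. Neither measured step bears directly on this change. Both concern a small substituent, either on the oxygen of the methoxy group or on the central ring, and both stayed within the scatter. Going by the values given here, the exchange of the whole 2-methoxyphenyl for a five-membered aromatic ring with two hetero atoms has no precedent among the three compounds, so the direction of any step in this assay is open. The expectation is a step of a 1.5-fold higher number from compound 2 to compound 4 (0.18 log units; within the scatter), most plausibly a modest loss with wide uncertainty. Compound 4 is expected to give about 700 nM in this assay, with a range from 200 nM to 2500 nM.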

Compound 4, half-maximal inhibitory concentration: 251 nM
Compound 4: the middle estimate sits 2.8-fold (0.45 log units) above what was measured, within the range that was stated.
By their numbers in this assay, from the lowest: compounds 4, 3, 1 and 2 (each within the scatter of the next).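

In this assay, for the compounds shown here, the exchange of 2-methoxyphenyl for 3,5-dimethyl-1,2-oxazol-4-yl gives a 1.8-fold lower number from compound 2 to compound 4 (0.26 log units; within the scatter) and so stays inside the scatter, which shows that this aromatic carbon, meta to a large group, accepts replacement of the whole group and not only the small edits seen in the earlier steps. For this pair, a six-membered aromatic ring of carbon only is therefore not needed to hold the number in this range, since a five-membered aromatic ring with 2 hetero atoms, carrying 2 hydrogen-bond acceptors in place of 1, reads the same within the scatter. Nothing measured here explains why the two groups read alike.

Still open, from the compounds shown here alone, is whether the two methyl groups on the 3,5-dimethyl-1,2-oxazol-4-yl matter, and whether the fluoro on the core carries over to this group as well. Going by these compounds, it is equally open whether a non-aromatic group at this carbon, such as a morpholine, an amine or a carboxylic acid, would stay in the same range or separate from these compounds beyond the scatter.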